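Lengthening the acid chain on the isoflavone-type ether series

A few compounds are considered here, and "the series" means these few. Any claim that something is new, unique, unknown or untested is made for them only; others in the source may bear on it.

Three compounds share one core and differ only in the chain hanging from the aromatic ether oxygen. Compound 1 `O=c1c(-c2ccc(O)cc2)coc2cc(OCCCBr)ccc12` carries a bromo end and gives 100% in a functional assay on mitochondria (Cricetulus griseus) for inhibition of Monoamine oxidase (Homo sapiens), tested at 9 uM; a lower number here means a weaker effect, a higher number a stronger effect of the compound at the concentration tested. Compound 2 `O=C(O)CCCCCCOc1ccc2c(=O)c(-c3ccc(O)cc3)coc2c1` carries a carboxylic acid end and gives 94.6% in this assay. Compound 3 `O=c1c(-c2ccc(O)cc2)coc2cc(OCCC3OCCCO3)ccc12` closes the chain end into a cyclic acetal and gives 88.5% in this assay. Compound 3 stands at the low end of the three numbers: one step is a number 6.1 percentage points lower from compound 2 to compound 3 (within the scatter), the other is a number 11.5 percentage points lower from compound 1 to compound 3 (beyond the scatter).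

Compound 4 `O=C(O)CCCCCCCCCOc1ccc2c(=O)c(-c3ccc(O)cc3)coc2c1` is the untested member. Relative to compound 3 the change is a group of 10 heavy atoms (8 carbon, 2 oxygen; no ring) in place of a group of 6 heavy atoms (4 carbon, 2 oxygen; one six-membered non-aromatic ring with 2 hetero atoms), on a saturated chain carbon, two bonds along the chain from an oxygen on an aromatic ring. Compound 4 thus returns to an acid-ended chain, as in compound 2, but longer. The step that bears most directly is a number 6.1 percentage points lower from compound 2 to compound 3 (within the scatter), which is within the scatter; a number 5.4 percentage points lower from compound 1 to compound 2 (within the scatter) is within the scatter too. A small rise toward compound 2 is therefore expected, not a step beyond the scatter, and compound 4 is estimated at 92% in this assay, between 80% and 100%, which corresponds to an expected step of a number 3.5 percentage points higher from compound 3 to compound 4 (within the scatter).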

Compound 4, a percentage reported as inhibition, at one concentration (the size of the read-out at that concentration, not a potency): 95%
Estimate against measurement, compound 4: 3 percentage points below; the range from low to high includes it.
By their numbers in this assay, from the lowest: compounds 3, 2, 4 and 1 (each within the scatter of the next, the first and the last beyond it).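

In this assay, lengthening the acid-ended chain to the 7-carboxyheptyl group gives no separable change at this position: the step is a number 0.4 percentage points higher from compound 2 to compound 4 (within the scatter), so the two acid-ended chains cannot be told apart at the concentration tested. Compound 4 also cannot be separated from the other two chain ends, with a number 6.5 percentage points higher from compound 3 to compound 4 (within the scatter) and a number 5 percentage points lower from compound 1 to compound 4 (within the scatter), even though compound 1 and compound 3 themselves lie beyond the scatter of each other. The compounds therefore add a chain with more heavy atoms and an open acid end without any resolved shift in the read-out, and no supporting measurement is available to explain this.

Whether an amine or a methyl ester at the end of the chain would hold the read-out at this level remains open, as does the effect of an acid-ended chain much shorter or longer than those shown. Each number is also a read-out at one concentration, so any difference in potency among these four compounds remains unresolved.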